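Little Movement Expected from Compound 3 to Compound 4

The source may report more compounds than this note shows. Statements on the series, on what has been measured and on what is new or still open speak of the compounds shown alone.

Of the compounds shown here, three sharing one core have been tested in a functional assay on SK-OV-3 cells (Homo sapiens) for antiproliferative activity, read by MTT assay, with a stated time of 24 h; a higher number here means a weaker inhibitor, a lower number a stronger inhibitor. Compound 1 `COc1ccc(C(=O)/C=C/c2ccc(F)cc2)c2c1C=CC(C)(C)O2` gives > 10000 nM, which is a limit of the assay and not a number. Compound 2 `COc1ccc(C(=O)/C=C/c2cccc([N+](=O)[O-])c2)c2c1C=CC(C)(C)O2` gives 9720 nM. Compound 3 `COc1ccc(C(=O)/C=C/c2ccc(O)c(Br)c2)c2c1C=CC(C)(C)O2` gives > 10000 nM, which is again only a limit. The series therefore sits mostly at the limit of > 10000 nM in this assay, at which 2 of the 3 values shown sit. Compound 4 `COc1ccc(C(=O)/C=C/c2cc(Cl)ccc2O)c2c1C=CC(C)(C)O2` changes the same group that varies among these compounds: 5-chloro-2-hydroxyphenyl in place of 3-bromo-4-hydroxyphenyl on a double-bonded chain carbon bound to a double-bonded chain carbon. The measured swaps of that group, an at least 1.0-fold lower number from compound 1 to compound 2 (0.01 log units; that floor lies within the scatter) and an at least 1.0-fold higher number from compound 2 to compound 3 (0.01 log units; that floor lies within the scatter), show no readable step beyond the scatter. No step beyond the scatter is therefore expected in this assay, and the estimated step is a number no higher from compound 3 to compound 4 (the limit leaves the size open). Compound 4 is expected near 10000 nM, with an estimated range of 5000 nM to 20000 nM.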

Compound 4, half-maximal inhibitory concentration: 6270 nM
Beside the measured number, compound 4's estimate is 1.6-fold (0.20 log units) above it, and the stated range covers the measured number.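

In this assay, the 5-chloro-2-hydroxyphenyl group gives a readable number at this position, where the 3-bromo-4-hydroxyphenyl group gave only a limit, but the steps remain small: an at least 1.5-fold lower number from compound 3 to compound 4 (0.20 log units; that floor lies within the scatter), an at least 1.5-fold lower number from compound 1 to compound 4 (0.20 log units; that floor lies within the scatter) and a 1.6-fold lower number from compound 2 to compound 4 (0.19 log units; within the scatter). This change, like the earlier ones, therefore shows no step readable beyond the scatter, and the series stays crowded at one end of the assay: the limit of > 10000 nM in this assay, at which 2 of the 4 values shown sit.

The compounds shown cannot separate the part played by the chlorine from that played by the hydroxyl. On these data alone, whether an amine or a carboxylic acid on this phenyl ring would give a step beyond the scatter stays open.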